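A few compounds are considered here, and "the series" means these few. Any claim that something is new, unique, unknown or untested is made for them only; others in the source may bear on it.

Three close relatives share one core. Compound 1 `CN1CCN(CCCCOc2c(O)cc(O)c3c(=O)cc(-c4ccccc4)oc23)CC1` carries a long chain bearing a ring with two nitrogens, compound 2 `CC(CO)NCCOc1c(O)cc(O)c2c(=O)cc(-c3ccccc3)oc12` carries a shorter chain ending in an amino alcohol, and compound 3 `CN(C)CCCCOc1c(O)cc(O)c2c(=O)cc(-c3ccccc3)oc12` has not yet been tested. Among the compounds with values here, in a functional assay on A549 cells (Homo sapiens) for cytotoxicity, read by MTT assay, with a stated time of 48 h (a lower number here means a stronger inhibitor, a higher number a weaker inhibitor), compound 1 gives a limit of the assay, > 100000 nM, and the single value shown sits at that limit (the limit of > 100000 nM in this assay, at which 1 of the 2 values shown sits). For compound 2 the outcome in this assay is "not determined" (no result reported), so compound 2 stands without a number. The change from compound 2 to compound 3 is 2-(dimethylamino)ethyl in place of (1-(hydroxymethyl)ethyl)amino on a saturated chain carbon, two bonds along the chain from an oxygen on an aromatic ring. Within the data shown here, no measured step shows how such a change moves this read-out, so no shift beyond the usual scatter can be foreseen in either direction. Compound 3 is expected to give roughly 80000 nM in this assay, most likely between 20000 nM and 300000 nM.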

Compound 3, half-maximal inhibitory concentration: > 100000 nM
Compound 3: a limit, no number; the forecaster's own chance of this, stated with the estimate: 60%; middle value at least 1.2-fold (0.09 log units) from the limit.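

Within the data shown here, compound 1 and compound 3 each give only a limit of the assay, so no step between them can be read. The compounds shown leave open whether changing the chain moves the read-out at all in this assay.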